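A few compounds are considered here, and "the series" means these few. Any claim that something is new, unique, unknown or untested is made for them only; others in the source may bear on it.

In a physicochemical assay for lipophilicity (on this read-out higher numbers stand for higher lipophilicity and lower numbers for lower lipophilicity), the measured compounds are:

compound 1, `CCC(C)(C)Oc1ccc(CC2SC(=O)NC2=O)cc1`: 3.76
compound 2, `CCC(C)(C)Oc1ccc(/C=C2\SC(=O)NC2=O)cc1`: 3.49
compound 3, `CC(C)COc1ccc(CC2SC(=O)NC2=O)cc1`: 3.36

Compound 1 and compound 3 differ in one place, (isobutyl in place of 1,1-dimethylpropyl on an oxygen on an aromatic ring), and this change produced a number 0.40 log units lower from compound 1 to compound 3 (beyond the scatter). Compound 1 and compound 2 share the same substituent on the oxygen but have different cores; how the two cores differ is not broken down here, and their two values lie within the usual scatter of each other.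

Compound 4, `CC(C)COc1ccc(/C=C2\SC(=O)NC2=O)cc1`, is not yet measured. It stands to compound 2 as compound 3 stands to compound 1: the same change, (isobutyl in place of 1,1-dimethylpropyl on an oxygen on an aromatic ring). Because the change from compound 1 to compound 3 gave a number 0.40 log units lower from compound 1 to compound 3 (beyond the scatter), compound 4 is expected to show a number 0.40 log units lower from compound 2 to compound 4 (beyond the scatter), a step of about the same size. On this basis compound 4 is estimated at 3.09, between 2.8 and 3.4.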

Compound 4, partition coefficient: 3.09
Estimate against measurement, compound 4: no gap at the digits printed; the measured number falls inside the stated range.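

In this assay the change from 1,1-dimethylpropyl to isobutyl on an oxygen on an aromatic ring gave a number 0.40 log units lower from compound 2 to compound 4 (beyond the scatter) on one core and a number 0.40 log units lower from compound 1 to compound 3 (beyond the scatter) on the other, so the step carried over between these two cores at the same size. This rests on a single pair of cores and a single change, and it does not show that the step would hold on any other core or for any other pair of groups. Nothing given here accounts for the size of the step or for its repeat.

The compounds shown leave open how the read-out would respond to a longer chain such as n-hexyl on that oxygen. They also leave open what an amine or a carboxylic acid in that place would do on either core.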